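This account rests on a few compounds, and the source may have more. Where it says the series, first, only, none or still open, it means among the compounds named here.

In an ADME assay on MDBK cells (Bos taurus) for cytotoxicity (on this read-out higher numbers stand for lower toxicity in this test and lower numbers for higher toxicity in this test), three compounds have been measured so far, and none of them returns a number. Compound 1 (`Fc1cccc(F)c1Cn1cccc2nc(-c3c(F)cccc3F)nc1-2`) gives > 100000 nM, which is a limit of the assay. Compound 2 (`Cc1ccn(Cc2c(F)cccc2F)c2nc(-c3c(F)cccc3F)nc1-2`) gives > 100000 nM, which is also a limit. Compound 3 (`Cc1ccc(Cn2ccc3nc(-c4ccccc4)nc-3c2)cc1`) gives > 100000 nM, again a limit, so its standing is known only as a limit and not as a value. Taken together, the data show (the limit of > 100000 nM in this assay, at which 3 of the 3 values shown sit).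

The next step leads to compound 4 (`Fc1cccc(Cn2ccc3nc(-c4ccccc4)nc-3c2)c1`), with 3-fluorophenyl in place of 4-methylphenyl on a saturated chain carbon bound to an aromatic nitrogen.

Among the measured compounds shown here, only one measured step is available for comparison, a step that the two limits leave unreadable from compound 1 to compound 2. It involves a different change, methyl in place of hydrogen on an aromatic carbon, and gives no size to carry over. The limit of compound 3, > 100000 nM, is therefore the only anchor, and no step beyond the scatter is expected in this assay, in either direction. The estimated change is a number no higher from compound 3 to compound 4 (the limit leaves the size open). Compound 4 is expected at about 100000 nM, with an estimated range from 50000 nM to 200000 nM, and the assay will most likely report a limit again.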

Compound 4, half-maximal cytotoxic concentration: > 100000 nM
Compound 4 ended at the assay's limit; the forecaster's own chance of this, stated with the estimate: 85%; the middle value sits exactly at the limit.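

Compound 3 and compound 4 both end at a limit in this assay, so the step between them cannot be read. The compounds shown leave open what actual number any of them would return and whether any of these changes moves the read-out at all, since all of them stand at one mark: the limit of > 100000 nM in this assay, at which 4 of the 4 values shown sit.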